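The source may hold more compounds than are shown below. What is called first, only, known or untested is meant among the compounds shown, and "the series" means these compounds.

Measured so far in an assay on HT-29 cells for inhibition of Serine-protein kinase ATM (Homo sapiens), read by fluorescence, with a stated time of 1 h; a lower number here means a stronger inhibitor, a higher number a weaker inhibitor:

compound 1 `CCC(CC)CNc1c(C(N)=O)cnc2ccc(C#N)cc12`: 820 nM
compound 2 `CCC(CC)CNc1c(C(N)=O)cnc2ccc(-c3ccc(COC)cc3)cc12`: 373 nM
compound 3 `CCC(CC)CNc1c(C(N)=O)cnc2ccc(-c3cncnc3)cc12`: 1840 nM

Compound 3 stands highest of the three numbers in this assay. The steps that reach it are a 2.2-fold higher number from compound 1 to compound 3 (0.35 log units; beyond the scatter) and a 4.9-fold higher number from compound 2 to compound 3 (0.69 log units; beyond the scatter), both beyond the scatter, so compound 3 is the weakest of the measured set. Compound 2 holds the lowest number, reached by a 2.2-fold lower number from compound 1 to compound 2 (0.34 log units; beyond the scatter).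

Compound 4 `CCC(CC)CNc1c(C(N)=O)cnc2ccc(-c3ccc(COC)nc3)cc12` is the next compound, differing from compound 3 in one place: 6-(methoxymethyl)pyridin-3-yl in place of pyrimidin-5-yl on an aromatic carbon. The entering group carries the methoxymethyl substituent found in compound 2 together with a single hetero atom in the ring, where compound 3 had two. The measured step that bears on this most directly is a 4.9-fold higher number from compound 2 to compound 3 (0.69 log units; beyond the scatter); the new group sits part way along that change, so a step toward a lower number is expected, smaller in size than that one. For compound 4 the expected step is a 2.8-fold lower number from compound 3 to compound 4 (0.45 log units; beyond the scatter). Compound 4 is therefore estimated at 650 nM, with a range of 280 nM to 1500 nM.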

Compound 4, half-maximal inhibitory concentration: 45 nM
The estimate for compound 4 lay 14-fold (1.16 log units) above the measured number; the measured number lies below the stated range.
By their numbers in this assay, from the lowest: compound 4; then compound 2; then compound 1; then compound 3.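

In this assay, within the data shown here, the group on this aromatic carbon can move the number much further than the earlier compounds showed: their steps were all modest, while the 6-(methoxymethyl)pyridin-3-yl group gives large steps against pyrimidin-5-yl (a 41-fold lower number from compound 3 to compound 4 (1.61 log units; beyond the scatter)) and cyano (an 18-fold lower number from compound 1 to compound 4 (1.26 log units; beyond the scatter)). The methoxymethyl substituent alone does not set the number, as compound 2 carries it too, and replacing 4-(methoxymethyl)phenyl with 6-(methoxymethyl)pyridin-3-yl still gives a modest but clear step (an 8.3-fold lower number from compound 2 to compound 4 (0.92 log units; beyond the scatter)). No measurement at hand explains the size of these steps.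

Open, from the compounds shown here alone, is whether the methoxymethyl substituent can be replaced on the pyridine ring, for instance by a dimethylaminomethyl group, a carboxylic acid or a longer ether chain. Also open, going by these compounds, is how the pyridine ring alone, without any such substituent, compares with compound 4.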